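Cyclobutyl for 2-hydroxycyclohexyl on the ring nitrogen

The compounds below may be only part of what the source reports. "The series", "measured", "known", "first", "only" and "open" are said of these compounds alone.

Measured so far:
compound 1, `Nc1ncnc2c1c(Oc1cc(C(F)(F)F)ccn1)nn2[C@@H]1CCCC[C@H]1O`: 1.1 h
compound 2, `Nc1ncnc2c1c(Oc1cc(O)ccn1)nn2C1CCC(F)(F)CC1`: 1.13 h
compound 3, `N#Cc1ccnc(Oc2nn([C@H]3C[C@@H](O)C3)c3ncnc(N)c23)c1`: > 2.41 h

The series was run in an ADME assay on microsomes from liver (Mus musculus) for metabolic stability, read by LC-MS, using NADPH, with a stated time of 10 min, tested at 10 uM; on this read-out higher numbers stand for a longer-lived compound and lower numbers for a shorter-lived compound. Compound 1 gives 1.1 h, the lowest of the two numbers shown; compound 2 sits close by, within the scatter, so no order between the two is claimed. For compound 3 the result is a limit of the assay, (the limit of > 2.41 h in this assay, at which 1 of the 3 values shown sits), and not a number.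

Compound 4, `Nc1ncnc2c1c(Oc1cc(C(F)(F)F)ccn1)nn2C1CCC1`, differs from compound 1 in one place: cyclobutyl in place of 2-hydroxycyclohexyl on an aromatic nitrogen. Among the compounds with values here, no pair of measured compounds separated by a single change is available, so the expected size of the step rests on compound 1 alone. The expectation is for no move beyond the scatter, with the step from compound 1 to compound 4 estimated as a 1.1-fold lower number from compound 1 to compound 4 (0.04 log units; within the scatter). Compound 4 is therefore expected to show about 1 h in this assay, with a range from 0.5 h to 2.4 h.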

Compound 4, half-life: 0.128 h
Estimate against measurement, compound 4: 7.8-fold (0.89 log units) above; measured number below the stated range.
By their numbers in this assay, from the lowest: compound 4; then compounds 1 and 2 (each within the scatter of the next). At a limit, above all of these: compound 3.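

Cyclobutyl in place of 2-hydroxycyclohexyl on this aromatic nitrogen gives, in this assay, an 8.6-fold lower number from compound 1 to compound 4 (0.93 log units; beyond the scatter), the first single-change step in the series and the first sign that this position can move the half-life beyond the scatter. The change alters several things at once: ring size, the hydrogen-bond donor and acceptor, and the defined stereocentres, so the step cannot be assigned to any one of them. Nothing measured here gives a cause for the step.

From the compounds shown here alone, whether the step follows the ring or the hydroxy group remains open, and plain cyclohexyl on the same core would separate the two. Going by these compounds, it is also open whether an amine on the cyclohexyl ring would give a half-life like that of compound 1 or that of compound 4.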